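Swapping 2-hydroxyphenyl for pyridin-4-yl: a stability estimate

The compounds below may be only part of what the source reports. "The series", "measured", "known", "first", "only" and "open" are said of these compounds alone.

Measured in an ADME assay on microsomes from liver (Homo sapiens) for metabolic stability, read by LC-MS, with a stated time of 30 min, tested at 0.5 uM; a higher number here means that more of the compound is left, a lower number that less of the compound is left:
compound 1 `c1ccc(-c2nc(-c3csc(N=C4NCCCN4)n3)cs2)cc1`: 83%
compound 2 `Oc1ccccc1-c1nc(-c2csc(N=C3NCCCN3)n2)cs1`: 30%

Among the compounds with values here, of the two measured compounds, compound 2 stands lowest at 30%, and the only other number, that of compound 1, lies above it beyond the scatter. Compound 3 `c1cc(-c2nc(-c3csc(N=C4NCCCN4)n3)cs2)ccn1` has not yet been measured in this assay. It differs from compound 2 as follows: pyridin-4-yl in place of 2-hydroxyphenyl on an aromatic carbon. Within the data shown here, one measured step bears on this change: a number 53 percentage points lower from compound 1 to compound 2 (beyond the scatter). That large step came with hydroxy in place of hydrogen on an aromatic carbon. Among the measured compounds shown here, compound 3 carries no hydroxy, like compound 1 at 83%, so a large rise is expected, although no measured compound contains pyridin-4-yl. The expected change is a number 42 percentage points higher from compound 2 to compound 3 (beyond the scatter). For compound 3 the estimated value is 72%, with an expected range of 50% to 90%.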

Compound 3, percent of the compound remaining: 58%
For compound 3 the middle estimate is 14 percentage points above the measured one; the measured number falls inside the stated range.
By their numbers in this assay, from the lowest: compound 2; then compound 3; then compound 1.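

In this assay, the hydroxy turns out not to be the whole story at this position. Pyridin-4-yl in place of 2-hydroxyphenyl gives a number 28 percentage points higher from compound 2 to compound 3 (beyond the scatter) and so recovers only part of the earlier loss, while pyridin-4-yl in place of phenyl gives a number 25 percentage points lower from compound 1 to compound 3 (beyond the scatter) even though neither group carries a hydroxy, which shows that a ring nitrogen in this group also goes with less compound left. Nothing in the available data explains either step.

From the compounds shown here alone, whether this drop belongs to pyridin-4-yl alone or would also appear with pyridin-3-yl or pyridin-2-yl remains open. Also open, going by these compounds, is how a phenyl ring bearing a methoxy, a fluorine or an amine would compare with compound 1 and compound 2 at this aromatic carbon.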